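Adding a dimethylamino group to the crotonamide of compound 1

A few compounds are considered here, and "the series" means these few. Any claim that something is new, unique, unknown or untested is made for them only; others in the source may bear on it.

Measured compounds:
compound 1 `C/C=C/C(=O)Nc1cc2c(N3CCc4ccccc43)ncnc2cc1OC` 8120 nM
compound 2 `C=C(C)C(=O)Nc1cc2c(N3CCc4ccccc43)ncnc2cc1O[C@@H]1CCOC1` 4910 nM
compound 3 `C/C=C/C(=O)Nc1cc2c(N3CCc4ccccc43)ncnc2cc1O[C@@H]1CCOC1` 5220 nM

In a functional assay on PC-3 cells (Homo sapiens) for antiproliferative activity, read by MTT assay, with a stated time of 72 h (a lower number here means a stronger inhibitor, a higher number a weaker inhibitor), compound 1 gives 8120 nM, while compound 3 gives 5220 nM and compound 2 gives 4910 nM. The step of a 1.6-fold lower number from compound 1 to compound 3 (0.19 log units; within the scatter) lies within the scatter. The gap between compound 1 and compound 2 also lies within the scatter, so compound 1 stands together with the other two rather than apart from them.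

Compound 4 `COc1cc2ncnc(N3CCc4ccccc43)c2cc1NC(=O)/C=C/CN(C)C` differs from compound 1 in one place: dimethylamino in place of hydrogen on a saturated chain carbon bound to a double-bonded chain carbon. Neither measured step touches this position. The step of a 1.6-fold lower number from compound 1 to compound 3 (0.19 log units; within the scatter) changes the group on the ether oxygen, and the step of a 1.1-fold higher number from compound 2 to compound 3 (0.03 log units; within the scatter) changes the unsaturated acyl group itself; both are within the scatter. For the measured compounds named here, the data therefore give no step that bears on the new group, and the expectation for this assay is no change beyond the scatter.

Compound 4 is estimated at 6000 nM, within the range 2000 nM to 18000 nM, which means an expected step of a 1.4-fold lower number from compound 1 to compound 4 (0.13 log units; within the scatter).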

Compound 4, half-maximal inhibitory concentration: 2190 nM
Compound 4: the middle estimate sits 2.7-fold (0.44 log units) above what was measured; the measured number falls inside the stated range.
By their numbers in this assay, from the lowest: compound 4; then compounds 2, 3 and 1 (each within the scatter of the next).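

In this assay the saturated chain carbon bound to a double-bonded chain carbon proves to be a position that responds: dimethylamino in place of hydrogen there gives a 3.7-fold lower number from compound 1 to compound 4 (0.57 log units; beyond the scatter) and this modest step is the only one shown that lies beyond the scatter. The earlier steps, on the ether oxygen and in the unsaturated acyl group, did not separate their compounds, so among the changes shown only this one moves the number clearly. Nothing measured here accounts for the step.

From the compounds shown here alone, it remains open whether dimethylamino would give a like step on compound 3, which carries oxolan-3-yl on the ether oxygen. Also open, going by these compounds, is whether another amine at the same carbon, such as a piperidine or a morpholine, or a longer chain carrying the dimethylamino group, would do the same.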